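Methoxy for Hydrogen, Second Occurrence in the Series

The source may report more compounds than this note shows. Statements on the series, on what has been measured and on what is new or still open speak of the compounds shown alone.

The series is followed in a functional assay on HeLa cells (Homo sapiens) for antiproliferative activity, read by sulforhodamine B assay, with a stated time of 48 h; a higher number here means a weaker inhibitor, a lower number a stronger inhibitor. Compound 1 `COc1cc(OC)c2sc(-c3ccc(N/C=C\C(=O)c4ccc(OC)c(O)c4)c(C)c3)nc2c1` gives 16100 nM in this assay. Compound 2 `COc1ccc(C(=O)/C=C\Nc2ccc(-c3nc4cc(OC)c(OC)c(OC)c4s3)cc2C)cc1O` gives 11400 nM. The change between them is methoxy in place of hydrogen on an aromatic carbon, and the step was a 1.4-fold lower number from compound 1 to compound 2 (0.15 log units; within the scatter).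

Compound 3 `COc1ccc(C(=O)/C=C\Nc2ccc(-c3nc4cc(OC)c(OC)c(OC)c4s3)cc2)cc1[N+](=O)[O-]` gives 11400 nM. Its value stands level with compound 2 at the digits recorded, and the two together are the lowest of the three numbers; against compound 1 the two values are apart by an amount within the scatter, so no order can be read between them. The difference between the core of compound 1 and the core of compound 3 is not broken down here.

Compound 4 `COc1cc(C(=O)/C=C\Nc2ccc(-c3nc4cc(OC)c(OC)c(OC)c4s3)cc2)cc([N+](=O)[O-])c1OC` is not yet measured. It differs from compound 3 by methoxy in place of hydrogen on an aromatic carbon. This is the same kind of change as that from compound 1 to compound 2, not the same change: there the carbon was part of a fused or bridged system of two rings, ortho to two methoxy groups, meta to a fused ring and para to a fused ring, whereas here the carbon is ortho to one methoxy group, meta to a large group and meta to a nitro group.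

The step from compound 3 to compound 4 is expected to be a 1.1-fold lower number from compound 3 to compound 4 (0.06 log units; within the scatter), set beside the measured 1.4-fold lower number from compound 1 to compound 2 (0.15 log units; within the scatter), and this rests on that earlier step having stayed within the scatter. For compound 4 the estimate in this assay is 10000 nM, with a range from 4500 nM to 22000 nM.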

Compound 4, half-maximal inhibitory concentration: 7800 nM
Estimate against measurement, compound 4: 1.3-fold (0.11 log units) above, and the stated range covers the measured number.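

In this assay, methoxy in place of hydrogen on an aromatic carbon gives a 1.5-fold lower number from compound 3 to compound 4 (0.16 log units; within the scatter), with the new methoxy ortho to a methoxy group, meta to a large group and meta to a nitro group. Set beside the earlier occurrence, on a carbon in a different setting, the two steps do not differ: the same change on two cores in this assay, a 1.4-fold lower number (0.15 log units; within the scatter) from compound 1 to compound 2 and a 1.5-fold lower number (0.16 log units; within the scatter) from compound 3 to compound 4, 1.0-fold (0.01 log units) apart, within the scatter of two such steps Across these two cores, then, the change carries over without any step beyond the scatter, but this does not establish that methoxy at either place lowers the number, and two occurrences say nothing about how the change would behave on any further core.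

The compounds shown leave open whether a different group on the same aromatic carbon, such as an amine, a carboxylic acid or a longer alkoxy chain, would give a step beyond the scatter in this assay. They also leave open how the methoxy step would read with the nitro group of compound 3 and compound 4 replaced by an amine, and whether any step seen here would hold on a cell line other than the one shown.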